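This account rests on a few compounds, and the source may have more. Where it says the series, first, only, none or still open, it means among the compounds named here.

Of the compounds shown here, two built on a shared core have been measured in an ADME assay on liver for metabolic stability, with Liver microsome (Rattus norvegicus) as the target, using microsomes, with a stated time of 10 min, tested at 0.5 uM; on this read-out lower numbers stand for a less stable compound and higher numbers for a more stable compound. Compound 1 (`Cc1noc(C)c1[C@@H]1C[C@@](C)(c2cc(NC(=O)c3ccc(Cl)cn3)c(F)cc2F)N=C(N)S1`) gives 76%, and compound 2 (`Cc1noc(C)c1[C@@H]1C[C@@](C)(c2cc(NC(=O)c3ccc(Cl)cn3)cc(F)c2F)N=C(N)S1`) gives 63%. Compound 2 is therefore the lower of the two, and its gap to compound 1 lies beyond the usual scatter. Compound 3 (`Cc1noc(C)c1[C@@H]1C[C@@](C)(c2cc(F)cc(NC(=O)c3ccc(Cl)cn3)c2)N=C(N)S1`) differs from compound 2 by a single change, hydrogen in place of fluoro on an aromatic carbon. For the measured compounds named here, no two measured compounds differ in one place only, so the data offer no direct guide to this change. Starting from compound 2 at 63%, a small downward shift is expected, possibly none beyond the scatter. The expected size of this shift is a number 4 percentage points lower from compound 2 to compound 3 (within the scatter). For compound 3 the estimated value in this assay is 59%, with an expected range from 44% to 74%.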

Compound 3, percent of the compound remaining: 26%
Estimate against measurement, compound 3: 33 percentage points above; the measured number lies below the stated range.
By their numbers in this assay, from the lowest: compound 3; then compound 2; then compound 1.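

In this assay, hydrogen in place of fluoro on an aromatic carbon, ortho to a fluoro group, ortho to a large group and para to a ((5-chloropyridin-2-yl)carbonyl)amino group, comes out as a number 37 percentage points lower from compound 2 to compound 3 (beyond the scatter). For the compounds shown here, this is the first step that changes one place only, and it shows that a single fluoro group at this position can weigh heavily on this read-out, leaving compound 3 at 26%. Nothing available here bears on why the number falls so far.

On these data alone, whether this carbon needs fluoro specifically stays open, since chloro, methyl or methoxy in the same place would show if another group holds the value of compound 2. Also open, as far as these compounds go, is whether the remaining fluoro group of compound 3 matters as much, and whether the step has the same size on other cores.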